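Trimethoxyphenyl Replacement in Coumarin-Linked Dienone Growth Inhibitors

The compounds below may be only part of what the source reports. "The series", "measured", "known", "first", "only" and "open" are said of these compounds alone.

Measured compounds:
compound 1 `COc1cc(/C=C/C(=O)/C=C/c2ccccc2)ccc1OCc1cn(CCCCOc2cc(=O)oc3ccccc23)nn1`: 31%
compound 2 `COc1cc(/C=C/C(=O)/C=C/c2cc(OC)c(OC)c(OC)c2)ccc1OCc1cn(CCCCOc2cc(=O)oc3ccccc23)nn1`: 60%
compound 3 `COc1cc(/C=C/C(=O)/C=C/c2ccccc2)ccc1OCc1cn(CCCOc2cc(=O)oc3ccccc23)nn1`: 43%

Of the compounds shown here, three have been tested in a functional assay on COLO 205 cells (Homo sapiens) for inhibition, read by sulforhodamine B assay, with a stated time of 48 h, tested at 50 uM; on this read-out higher numbers stand for more inhibition of growth at the one concentration tested and lower numbers for less inhibition of growth. In this assay compound 1 gives 31%, compound 2 gives 60% and compound 3 gives 43%.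

Compound 1 and compound 2 share one core and differ in a single place: 3,4,5-trimethoxyphenyl in place of phenyl on a double-bonded chain carbon bound to a double-bonded chain carbon. This change brought a number 29 percentage points higher from compound 1 to compound 2 (beyond the scatter). Compound 3 carries a different core; the difference between the core of compound 1 and the core of compound 3 is not broken down here. On this assay compound 3 stands above compound 1 and below compound 2, both gaps lying beyond the usual scatter.

Compound 4 `COc1cc(/C=C/C(=O)/C=C/c2cc(OC)c(OC)c(OC)c2)ccc1OCc1cn(CCCOc2cc(=O)oc3ccccc23)nn1` has not yet been measured. It differs from compound 3 by 3,4,5-trimethoxyphenyl in place of phenyl on a double-bonded chain carbon bound to a double-bonded chain carbon. Among the compounds with values here, this is the same change as that between compound 1 and compound 2, made at the same place on the chain, so the earlier step is the only guide available. In this assay the expected step is a number 25 percentage points higher from compound 3 to compound 4 (beyond the scatter), because the same change gave a number 29 percentage points higher from compound 1 to compound 2 (beyond the scatter). Whether the change carries over unchanged onto the core of compound 3 is not known from these three compounds, which leaves the range wide. Compound 4 is therefore estimated at 68% in this assay, with a range from 52% to 82%.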

Compound 4, percent growth inhibition at one concentration: 74%
For compound 4 the middle estimate is 6 percentage points below the measured one, within the range that was stated.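

In this assay, 3,4,5-trimethoxyphenyl in place of phenyl on a double-bonded chain carbon bound to a double-bonded chain carbon gave a number 31 percentage points higher from compound 3 to compound 4 (beyond the scatter). Set beside the earlier step, the change carried over from one core to the other with its size kept: the same change on two cores in this assay, a number 29 percentage points higher (beyond the scatter) from compound 1 to compound 2 and a number 31 percentage points higher (beyond the scatter) from compound 3 to compound 4, 2 percentage points apart, within the scatter of two such steps. Within the data shown here, this agreement rests on only two cores, a single cell line and one tested concentration, so it does not show that the step would hold on a core further removed from these two, and it says nothing about why the exchange of groups raises the number.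

The compounds shown leave open whether the full set of three methoxy groups is needed, or whether a 4-methoxyphenyl, a 4-chlorophenyl or a phenyl bearing an amine or a carboxylic acid at the same place on the chain would bring a step of like size. They also leave open how a longer chain in the core would act with either phenyl or 3,4,5-trimethoxyphenyl, and whether the step seen in these cells appears in other cell lines or at other concentrations.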